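This account rests on a few compounds, and the source may have more. Where it says the series, first, only, none or still open, it means among the compounds named here.

Compound 3 `COc1cc(/C(=C\c2cn(C(C)=O)c3ccc(OCc4ccccc4)cc23)C(=O)O)cc(OC)c1OC` gives 59600 nM in a functional assay on LNCaP cells (Homo sapiens) for cytotoxicity, read by MTT assay, with a stated time of 72 h; on this read-out higher numbers stand for weaker inhibition and lower numbers for stronger inhibition. Its nearest neighbour is compound 1 `COc1cccc(/C(=C\c2cn(C(C)=O)c3ccc(OCc4ccccc4)cc23)C(=O)O)c1`, which in this assay gives 65100 nM; the step of a 1.1-fold lower number from compound 1 to compound 3 (0.04 log units; within the scatter) lies within the scatter, so the two compounds cannot be ranked. Compound 2 `COc1ccc(/C(=C\c2c[nH]c3ccc(OCc4ccccc4)cc23)C(=O)O)cc1` has no result in this assay, where compound 2 is recorded as "not determined" (no result reported). Compound 4 `CC(=O)n1cc(/C=C(/C(=O)O)c2ccc(Cl)cc2)c2cc(OCc3ccccc3)ccc21` differs from compound 3 by a single change: 4-chlorophenyl in place of 3,4,5-trimethoxyphenyl on a double-bonded chain carbon bound to a carbonyl carbon and a double-bonded chain carbon. Among the compounds with values here, the only measured step that bears on exchanging the ring at this place, a 1.1-fold lower number from compound 1 to compound 3 (0.04 log units; within the scatter), stayed within the scatter, so no step beyond the scatter is expected here either. The step of a 1.1-fold lower number from compound 3 to compound 4 (0.03 log units; within the scatter) is therefore estimated to be small. Compound 4 is expected to give 55000 nM in this assay, with a likely range from 20000 nM to 150000 nM.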

Compound 4, half-maximal inhibitory concentration: > 100000 nM
Compound 4: a limit, no number (the forecaster's own chance of this, stated with the estimate: 20%); middle value at least 1.8-fold (0.25 log units) from the limit.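

Compound 4 gives a limit and not a number in this assay: the limit of > 100000 nM in this assay, at which 1 of the 4 values shown sits. Swapping in 4-chlorophenyl on this double-bonded chain carbon therefore gives only floors, an at least 1.6-fold higher number from compound 3 to compound 4 (0.22 log units; that floor lies within the scatter) and an at least 1.5-fold higher number from compound 1 to compound 4 (0.18 log units; that floor lies within the scatter). Within the data shown here, this is the first ring exchange at this place that could exceed the scatter, but the floors do not establish that it does.

As far as these compounds go, it remains open whether the chlorine or the absence of methoxy groups matters more. How a ring bearing an amine would behave at this place is also unresolved.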